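A few compounds are considered here, and "the series" means these few. Any claim that something is new, unique, unknown or untested is made for them only; others in the source may bear on it.

Compound 3, `C[C@H](NC(=O)c1cc2ccccc2cn1)C(=O)OCc1ccccc1`, gives 154 nM in a functional assay on HeLa cells (Homo sapiens) for antiproliferative activity, read by MTT assay, with a stated time of 48 h (a higher number here means a weaker inhibitor, a lower number a stronger inhibitor), the lowest of the three numbers shown here. Compound 1, `CSCC[C@H](NC(=O)c1cc2ccccc2cn1)C(=O)OCc1ccccc1`, gives 309 nM, and compound 2, `O=C(C[C@H](NC(=O)c1cc2ccccc2cn1)C(=O)OCc1ccccc1)OCc1ccccc1`, gives 411 nM. The step of a 2.0-fold lower number from compound 1 to compound 3 (0.30 log units; within the scatter) lies within the scatter, while the step of a 2.7-fold lower number from compound 2 to compound 3 (0.43 log units; beyond the scatter) lies beyond it, so compound 3 is separated from compound 2 but not from compound 1.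

Compound 4, `CC[C@@H](C)[C@H](NC(=O)c1cc2ccccc2cn1)C(=O)OCc1ccccc1`, differs from compound 3 in one place: sec-butyl in place of methyl on a saturated chain carbon bound to an amide-type nitrogen and a carbonyl carbon. Among the compounds with values here, no measured pair repeats this exact change. The nearest guides are the two steps that remove a larger group from the side chain and arrive at compound 3: the step of a 2.0-fold lower number from compound 1 to compound 3 (0.30 log units; within the scatter) and the step of a 2.7-fold lower number from compound 2 to compound 3 (0.43 log units; beyond the scatter). Both point the same way, toward a higher number when the side chain is enlarged, with sizes from within the scatter to modest. Going from compound 3 to compound 4 adds a sec-butyl group, so a small rise in the number, at most modest, is expected. Compound 4 is therefore expected to show 300 nM, within a range of 130 nM to 750 nM, which corresponds to an expected step of a 1.9-fold higher number from compound 3 to compound 4 (0.29 log units; within the scatter).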

Compound 4, half-maximal inhibitory concentration: 185 nM
Estimate against measurement, compound 4: 1.6-fold (0.21 log units) above, and the stated range covers the measured number.
By their numbers in this assay, from the lowest: compounds 3, 4, 1 and 2 (each within the scatter of the next, the first and the last beyond it).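

The earlier side chains held sulfur or a benzyl ester, so they could not show what an all-carbon sec-butyl group does at this position; in place of methyl, it gives the step of a 1.2-fold higher number from compound 3 to compound 4 (0.08 log units; within the scatter) in this assay. Against the earlier compounds, the step of a 1.7-fold lower number from compound 1 to compound 4 (0.22 log units; within the scatter) also stays within the scatter, while the step of a 2.2-fold lower number from compound 2 to compound 4 (0.35 log units; beyond the scatter) does not. Enlarging the group here therefore does not by itself separate a compound from compound 3: of the four compounds, only compound 2, with its (benzyloxycarbonyl)methyl group, stands apart from compound 3 and compound 4.

On these data alone, whether an amine, a carboxylic acid or a longer carbon chain at this position would fit the same picture remains open. Nothing shown here offers an explanation for these steps.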